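The source may hold more compounds than are shown below. What is called first, only, known or untested is meant among the compounds shown, and "the series" means these compounds.

Among the compounds with values here, in a functional assay on MDA-MB-231 cells (Homo sapiens) for cytotoxicity, read by MTT assay (a higher number here means a weaker inhibitor, a lower number a stronger inhibitor), three compounds sharing one core have numbers so far. Compound 1 (`CCn1cc(-c2nc3ccc([N+](=O)[O-])cc3o2)c(=O)c2cc(F)c(N3CCNC(C)C3)c(F)c21`) gives 2000 nM, compound 2 (`CCn1cc(C(=O)Nc2ccccc2N)c(=O)c2cc(F)c(N3CCNC(C)C3)c(F)c21`) gives 9500 nM, and compound 3 (`CCn1cc(C(=O)Nc2ccc(Cl)cn2)c(=O)c2cc(F)c(N3CCNC(C)C3)c(F)c21`) gives 4800 nM. Compound 3 therefore lies beyond the scatter from compound 1, whose number is the lower of the two, but cannot be told apart from compound 2. Within the data shown here, the one measured step between compounds differing in a single place is a 2.0-fold lower number from compound 2 to compound 3 (0.30 log units; within the scatter), where 5-chloropyridin-2-yl replaced 2-aminophenyl on an amide-type nitrogen.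

Compound 4 (`CCn1cc(C(=O)Nc2ccc(C(C)=O)cc2)c(=O)c2cc(F)c(N3CCNC(C)C3)c(F)c21`) has not yet been measured. It departs from compound 3 at that same nitrogen: 4-acetylphenyl in place of 5-chloropyridin-2-yl on an amide-type nitrogen. Here 4-acetylphenyl enters in place of 5-chloropyridin-2-yl, so the new group also carries a six-membered aromatic ring. Among the measured compounds shown here, the only guide is the exchange between compound 2 and compound 3, which moved the number by a 2.0-fold lower number from compound 2 to compound 3 (0.30 log units; within the scatter). A single step is thin evidence, but it gives no reason to expect a large shift from another exchange at this nitrogen. The expected change is small, a 1.3-fold higher number from compound 3 to compound 4 (0.10 log units; within the scatter), and no shift beyond the scatter is anticipated. For compound 4 the estimated value is 6000 nM, with an expected range from 2500 nM to 14000 nM.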

Compound 4, half-maximal inhibitory concentration: 5600 nM
The estimate for compound 4 lay 1.1-fold (0.03 log units) above the measured number; the range from low to high includes it.
By their numbers in this assay, from the lowest: compound 1; then compounds 3, 4 and 2 (each within the scatter of the next).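

In this assay, replacing the 5-chloropyridin-2-yl group with 4-acetylphenyl gives a step within the scatter (a 1.2-fold higher number from compound 3 to compound 4 (0.07 log units; within the scatter)), and so does replacing 2-aminophenyl with 4-acetylphenyl (a 1.7-fold lower number from compound 2 to compound 4 (0.23 log units; within the scatter)). Within the data shown here, the earlier compounds offered only one exchange on this amide-type nitrogen, whereas three different aromatic groups can now be compared there, and no pair among compounds 2, 3 and 4 can be told apart, whether the six-membered aromatic ring holds a hetero atom or carbon only. No measurement is available that would explain this result.

The compounds shown leave open whether a group with no aromatic ring on this nitrogen, such as a cyclohexyl ring or a longer alkyl chain, or a phenyl ring carrying a carboxylic acid, would give a number beyond the scatter from these three amides. They also leave open whether compounds 2, 3 and 4 would remain this close in any other assay.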